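A few compounds are considered here, and "the series" means these few. Any claim that something is new, unique, unknown or untested is made for them only; others in the source may bear on it.

Compound 1 `O=C(NCc1ccccc1)c1ccc(N2CCN(S(=O)(=O)c3cccc(Cl)c3Cl)CC2)nn1` was tested in an ADME assay on microsomes from liver (Mus musculus) for metabolic stability, read by LC-MS, using NADPH, tested at 10 uM (a higher number here means that the compound lasts longer, a lower number that the compound disappears faster), and gave a half-life of 0.233 h. Compound 2 `N#Cc1ncccc1S(=O)(=O)N1CCN(c2ccc(C(=O)NCc3ccc(F)cc3)[n+]([O-])n2)CC1` gave 0.267 h in this assay, and compound 3 `O=C(NCc1ccc(F)cc1)c1ccc(N2CCN(S(=O)(=O)c3ccc(F)cc3C(F)(F)F)CC2)nn1` gave 0.2 h; the three numbers lie together, and none is separated from compound 1 beyond the usual scatter. Compound 4 `O=C(NCc1ccccc1)c1ccc(N2CCN(S(=O)(=O)c3ccccc3Cl)CC2)nn1` has not been measured in this assay. It differs from compound 1 in one place: hydrogen in place of chloro on an aromatic carbon. For the measured compounds named here, no measured pair shows this change, so the direction of its effect is unknown; with all three measured numbers so close, a step from compound 1 to compound 4 beyond the scatter is not expected. For compound 4 a half-life of 0.25 h is estimated, within a range of 0.12 h to 0.5 h, which means an expected step of a 1.1-fold higher number from compound 1 to compound 4 (0.03 log units; within the scatter).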

Compound 4, half-life: 0.0333 h
The estimate for compound 4 lay 7.5-fold (0.88 log units) above the measured number, outside the stated range (below it).
By their numbers in this assay, from the lowest: compound 4; then compounds 3, 1 and 2 (each within the scatter of the next).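

In this assay the change from 2,3-dichlorophenyl to 2-chlorophenyl gives a 7.0-fold lower number from compound 1 to compound 4 (0.84 log units; beyond the scatter), so this position, ortho to a chloro group and meta to a large group, is not indifferent: here chloro goes with the longer half-life and hydrogen with the shorter. The earlier compounds shown here held no pair that differed in one place and could not show this. Nothing shown gives a reason for the step. From the compounds shown here alone, whether methyl or methoxy at this position would keep the half-life of compound 1 stays open. So does whether this change has a similar effect in other compounds.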